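Flipping One Ring Stereocentre in a Chemokine Receptor Antagonist

This account rests on a few compounds, and the source may have more. Where it says the series, first, only, none or still open, it means among the compounds named here.

Compound 1 `CN(C[C@@H]1Cc2c(cccc2N2CCNCC2)CN1)[C@H]1CCCc2cccnc21`: 313 nM
Compound 2 `CC(C)N(C[C@H]1Cc2c(cccc2N2CCNCC2)CN1)[C@H]1CCCc2cccnc21`: 364 nM

In a functional assay on CCRF-CEM cells for antagonist activity at C-X-C chemokine receptor type 4 (Homo sapiens), read by calcium flux, with stated times of 25 min and 90 s (a lower number here means a stronger inhibitor, a higher number a weaker inhibitor), compound 1 gives 313 nM, the lowest of the two numbers, while compound 2 gives 364 nM, a gap within the usual scatter. Among the compounds with values here, compound 3 `CN(C[C@H]1Cc2c(cccc2N2CCNCC2)CN1)[C@H]1CCCc2cccnc21` is still to be measured. the two compounds have the same atoms and bonds and differ only in configuration as drawn: 1 of 2 stereo elements differ; a stereocentre at a saturated ring carbon is drawn S in compound 1 and R in compound 3 No measured pair shows the effect of such a change here, so the expected step from compound 1 to compound 3 is a 1.1-fold higher number from compound 1 to compound 3 (0.05 log units; within the scatter), with no clear direction beyond the scatter. Compound 3 is therefore estimated at 350 nM, with a range of 120 nM to 1000 nM.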

Compound 3, half-maximal inhibitory concentration: 6.08 nM
Beside the measured number, compound 3's estimate is 58-fold (1.76 log units) above it; the whole stated range lies above it.
By their numbers in this assay, from the lowest: compound 3; then compounds 1 and 2 (each within the scatter of the next).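

This ring stereocentre matters far more than the first two numbers suggested: with no atom or bond changed, the result is a 51-fold lower number from compound 1 to compound 3 (1.71 log units; beyond the scatter). The step can be traced to this stereocentre alone for one reason: the fact that compounds 1 and 3 differ only in the configuration as drawn The amine substituent matters as well, since methyl in place of isopropyl on an amine nitrogen gives a 60-fold lower number from compound 2 to compound 3 (1.78 log units; beyond the scatter).

As far as these compounds go, whether an ethyl group on that nitrogen would keep a number as low as that of compound 3 remains open. So does the effect of a hydrogen there.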